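Benzoate Ester Series: Anilide Replaces Methylamide

The source may hold more compounds than are shown below. What is called first, only, known or untested is meant among the compounds shown, and "the series" means these compounds.

The study measures ear-inflammation inhibition in the mouse with a functional assay on the whole organism (Ear) for inhibition, with Mus musculus as the target, at a dose of 40 mg/kg by the oral route; a lower number here means less inhibition, a higher number more inhibition at the dose given (going by the name of the read-out). Of the compounds shown here, two have numbers so far. Compound 1, with the structure `CC(=O)Oc1ccc(-c2ccc(F)cc2F)cc1C(=O)Nc1ccccc1C`, gives 19.6% in this assay. Compound 2, with the structure `CNC(=O)c1cc(-c2ccc(F)cc2F)ccc1OC(=O)c1ccccc1`, gives 68.9% in this assay. For the measured compounds named here, compound 2 stands highest of the two, and its gap to compound 1 lies beyond the scatter; no single-point step links the two, so the pair shows only that the benzoate-bearing methylamide reaches a higher number than the acetate-bearing anilide.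

Compound 3, with the structure `Cc1ccccc1NC(=O)c1cc(-c2ccc(F)cc2F)ccc1OC(=O)c1ccccc1`, has not yet been measured. It differs from compound 2 in one place: 2-methylphenyl in place of methyl on an amide-type nitrogen. Going by the values given here, the anilide it acquires is the one carried by compound 1, whose value 19.6% is the low end of the pair, while the benzoate of compound 2 is kept.

Compound 3 is therefore expected to fall, by a step of a number 28.9 percentage points lower from compound 2 to compound 3 (beyond the scatter) that goes downward and likely beyond the scatter. The estimated value of compound 3 is 40%, with a range from 15% to 65%.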

Compound 3, a percentage reported as inhibition, in the whole organism at one dose (the size of the read-out at that dose, not a potency): 21.4%
Estimate against measurement, compound 3: 18.6 percentage points above; low and high end bracket the measured number.
By their numbers in this assay, from the lowest: compounds 1 and 3 (each within the scatter of the next); then compound 2.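

In this assay, exchanging methyl for 2-methylphenyl on the amide-type nitrogen while keeping the benzoate gives a number 47.5 percentage points lower from compound 2 to compound 3 (beyond the scatter), which ties a large loss to this one place, something the earlier pair could not do because its two compounds differed in two places. The second single change, phenyl in place of methyl on a carbonyl carbon with the 2-methylphenyl amide kept, gives a number 1.8 percentage points higher from compound 1 to compound 3 (within the scatter), so among the compounds carrying that anilide, the acetate and the benzoate cannot be told apart at this dose. Between them, the two steps place the gap between compound 1 and compound 2 at the group on the amide-type nitrogen rather than at the ester, though nothing available explains why the number falls with this change.

On these data alone, it remains open whether the ester matters when the nitrogen carries methyl, since the benzoate has been compared with the acetate only on the anilide. As far as these compounds go, it also remains open where between methyl and 2-methylphenyl the number falls, a question that an ethyl group, a longer chain or an unsubstituted phenyl on the same nitrogen would address.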